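The compounds below may be only part of what the source reports. "The series", "measured", "known", "first", "only" and "open" are said of these compounds alone.

Measured in an ADME assay on BaF3 cells (Mus musculus) for cytotoxicity, read by CellTiter-Glo and CCK-8 assay, with a stated time of 72 h; on this read-out lower numbers stand for stronger inhibition of growth and higher numbers for weaker inhibition of growth:

Compound 1 `CCC(=O)NCc1ccc(C(=O)Nc2ccc(C)c(Nc3nccc(-c4cccnc4)n3)c2)cc1` gives only a limit, > 10000 nM.
Compound 2 `C=CC(=O)NCc1ccc(C(=O)Nc2ccc(C)c(Nc3nccc(-c4cccnc4)n3)c2)cc1` likewise gives only a limit, > 10000 nM.
Compound 3 `CCC(=O)NCc1cccc(C(=O)Nc2ccc(C)c(Nc3nccc(-c4cccnc4)n3)c2)c1` gives 4750 nM.

Compound 2 arises from compound 1 by vinyl in place of ethyl on a carbonyl carbon. The resulting step that the two limits leave unreadable from compound 1 to compound 2 cannot be read, because both values sit at the limit of > 10000 nM in this assay, at which 2 of the 3 values shown sit. Compound 4 `C=CC(=O)NCc1cccc(C(=O)Nc2ccc(C)c(Nc3nccc(-c4cccnc4)n3)c2)c1` stands to compound 3 in the same way, by vinyl in place of ethyl on a carbonyl carbon, the place being identical in both pairs; the difference between the core of compound 1 and the core of compound 3 is not broken down here. Going by the values given here, with the only precedent unreadable, the step from compound 3 to compound 4 is expected to be small, roughly a 1.1-fold lower number from compound 3 to compound 4 (0.02 log units; within the scatter), within the usual scatter. Compound 4 is thus estimated at 4500 nM, between 1500 nM and 14000 nM.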

Compound 4, concentration for 50% growth inhibition: > 10000 nM
Compound 4 gave a limit, no number; the forecaster's own chance of this, stated with the estimate: 35%; middle value at least 2.2-fold (0.34 log units) away from the limit.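

In this assay, vinyl in place of ethyl on a carbonyl carbon gives an at least 2.1-fold higher number from compound 3 to compound 4 (0.32 log units; beyond the scatter), a weakening of growth inhibition on this core. From the compounds shown here alone, compound 4 gives only a limit, > 10000 nM, so the true size of that step stays unknown. The same change on the core of compound 1 cannot be read, so these compounds do not show whether the effect carries from one core to the other: the limit of > 10000 nM in this assay, at which 3 of the 4 values shown sit.

Going by these compounds alone, compound 3 remains the only compound here with a measured number. Open, going by these compounds, is whether an amine or a longer chain in place of ethyl on that carbonyl carbon would give a readable number on either core.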